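Swapping benzyl for cyclopropyl on a ring amide nitrogen

The compounds below may be only part of what the source reports. "The series", "measured", "known", "first", "only" and "open" are said of these compounds alone.

Compound 1 `Cc1ccc(Nc2ncc3c(n2)N(Cc2ccccc2)C(=O)N(c2cc(NC(=O)c4ccc(C)c(C(F)(F)F)c4)ccc2C)C3)cn1` is tested in an ADME assay on BaF3 cells (Mus musculus) for inhibition, read by CellTiter-Glo, with a stated time of 72 h; a lower number here means a stronger inhibitor of growth, a higher number a weaker inhibitor of growth. Compound 1 does not reach a number in this assay: it sits at the limit > 5000 nM, which is a limit of the assay and not a measurement. Going by the values given here, the only other compound measured, compound 2 `CCN1CCN(C(=O)c2ccc(Nc3ncc4c(n3)N(C)C(=O)N(c3cc(NC(=O)c5ccc(CN6CCC(N(C)C)C6)c(C(F)(F)F)c5)ccc3C)C4)cn2)CC1`, differs from compound 1 in several places at once, and in this assay compound 2 gives 704 nM. Compound 3 `Cc1ccc(Nc2ncc3c(n2)N(C2CC2)C(=O)N(c2cc(NC(=O)c4ccc(C)c(C(F)(F)F)c4)ccc2C)C3)cn1` keeps the whole shared core of compound 1 and changes one thing: cyclopropyl in place of benzyl on an amide-type nitrogen in a ring. Among the compounds with values here, no measured pair shows what this exchange alone does, and the only thing known about compound 1 here is the limit (the limit of > 5000 nM in this assay, at which 1 of the 2 values shown sits). The step that the limit leaves unreadable from compound 1 to compound 3 is therefore expected to be small and uncertain in direction, most likely not beyond the scatter. Compound 3 is estimated at 6000 nM, within a range from 1500 nM to 20000 nM.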

Compound 3, concentration for 50% growth inhibition: 649 nM
The estimate for compound 3 lay 9.2-fold (0.97 log units) above the measured number, and the stated range ends above it.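

In this assay, the substituent on this amide-type nitrogen matters: cyclopropyl in place of benzyl gives an at least 7.7-fold lower number from compound 1 to compound 3 (0.88 log units; beyond the scatter). With the rest of the core of compound 1 unchanged, this single exchange is enough to bring compound 3 to a measurable number, something that compound 2, which differs in several places at once, could not show. The step gives only a minimum size and not an exact one, because compound 1 stands at a limit of the assay: the limit of > 5000 nM in this assay, at which 1 of the 3 values shown sits.

The compounds shown leave open whether the effect depends on the three-membered ring itself or simply on the loss of benzyl. A cyclobutyl group or a straight propyl chain on the same nitrogen would help to separate these two readings.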